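Chloro to ethoxy exchange on compound 3

This account rests on a few compounds, and the source may have more. Where it says the series, first, only, none or still open, it means among the compounds named here.

Measured compounds in an assay on cells for agonist activity at ecdysone receptor (Bombyx mori), read by a luciferase reporter, with a stated time of 24 h; on this read-out higher numbers stand for an effect only at larger amounts of compound and lower numbers for an effect already at smaller amounts:
compound 1 `CC(C)(C)N(NC(=O)c1cccc(C#N)c1)C(=O)c1ccccc1Cl`: 955 nM
compound 2 `Cc1cccc(C(=O)NN(C(=O)c2ccccc2Cl)C(C)(C)C)c1`: 603 nM
compound 3 `CCc1ccc(C(=O)NN(C(=O)c2ccccc2Cl)C(C)(C)C)cc1`: 5.75 nM

Compound 3 holds the lowest number of the three, with a 170-fold lower number from compound 1 to compound 3 (2.22 log units; beyond the scatter) and a 100-fold lower number from compound 2 to compound 3 (2.02 log units; beyond the scatter) both beyond the scatter; both of these steps lie on the other carbonyl aryl. Compound 4 `CCOc1ccccc1C(=O)N(NC(=O)c1ccc(CC)cc1)C(C)(C)C` differs from compound 3 by ethoxy in place of chloro on an aromatic carbon. For the measured compounds named here, no measured step touches this ring, so no measured step bears directly on the change; the only anchor is that compound 3 gives 5.75 nM in this assay. Expected for compound 4 is a modest rise in the number, a 2.6-fold higher number from compound 3 to compound 4 (0.42 log units; beyond the scatter), close to the edge of the scatter. Compound 4 is estimated at 15 nM, with a range from 4 nM to 60 nM.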

Compound 4, half-maximal effective concentration: 2880 nM
For compound 4 the middle estimate is 190-fold (2.28 log units) below the measured one, and the stated range ends below it.
By their numbers in this assay, from the lowest: compound 3; then compounds 2 and 1 (each within the scatter of the next); then compound 4.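

In this assay, for the compounds shown here, the exchange of 2-chlorophenyl for 2-ethoxyphenyl gives a 500-fold higher number from compound 3 to compound 4 (2.70 log units; beyond the scatter), so this ring, which no earlier step touched, also moves the number far beyond the scatter. At this place, ortho to a large group, chloro cannot be replaced by ethoxy without a large rise in the number. No measurement shown gives a reason for this step.

From the compounds shown here alone, it remains open whether the rise follows the oxygen or the two-carbon chain of ethoxy. Methoxy or fluoro at the same place would help separate these readings.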